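Aryl sulfonate exchange on the shared core

A few compounds are considered here, and "the series" means these few. Any claim that something is new, unique, unknown or untested is made for them only; others in the source may bear on it.

In a functional assay on DU-145 cells (Homo sapiens) for inhibition, read by MTT assay, with a stated time of 72 h (on this read-out lower numbers stand for stronger inhibition and higher numbers for weaker inhibition), compound 3 `O=C(O)CCCCCCC(=O)Nc1ccc(C2=C(c3ccc(O)cc3)C3CC(S(=O)(=O)Oc4ccc5ccccc5c4)C2O3)cc1` gives 58300 nM, the lowest of the two numbers in hand, though its nearest neighbour sits within the scatter. Compound 1 `O=C(O)CCCCCCC(=O)Nc1ccc(C2=C(c3ccc(O)cc3)C3CC(S(=O)(=O)Oc4ccc(C(F)(F)F)cc4)C2O3)cc1` gives 77000 nM in this assay, so the step is a 1.3-fold lower number from compound 1 to compound 3 (0.12 log units; within the scatter). Compound 2 `O=C(O)CCCCCCC(=O)Nc1ccc(C2=C(c3ccc(O)cc3)C3CC(S(=O)(=O)Oc4ccccc4C(F)(F)F)C2O3)cc1` reaches only a limit in this assay, namely (the limit of > 100000 nM in this assay, at which 1 of the 3 values shown sits), and is recorded as > 100000 nM. Against that limit the step is an at least 1.7-fold lower number from compound 2 to compound 3 (0.23 log units; that floor lies within the scatter), and between the two trifluoromethyl-bearing compounds it is an at least 1.2-fold higher number from compound 1 to compound 2 (0.11 log units; that floor lies within the scatter). All three compounds share the core and differ only in the group carried on the sulfonate oxygen; every exchange so far has stayed within the scatter.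

Compound 4 `Cc1ccccc1OS(=O)(=O)C1CC2OC1C(c1ccc(NC(=O)CCCCCCC(=O)O)cc1)=C2c1ccc(O)cc1` has not yet been measured in this assay. It differs from compound 3 by 2-methylphenyl in place of naphthalen-2-yl on an oxygen. For the measured compounds named here, the steps that bear on this change are the two earlier exchanges at the same oxygen, a 1.3-fold lower number from compound 1 to compound 3 (0.12 log units; within the scatter) and an at least 1.7-fold lower number from compound 2 to compound 3 (0.23 log units; that floor lies within the scatter), neither of which moved the number beyond the scatter. A 2-methylphenyl group is therefore expected to behave like the other single-ring aryl groups, giving an estimated step of a 1.3-fold higher number from compound 3 to compound 4 (0.11 log units; within the scatter), that is, no change beyond the scatter and possibly a slightly higher number. Compound 4 is expected to give about 75000 nM in this assay, with a range from 35000 nM to 160000 nM.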

Compound 4, half-maximal inhibitory concentration: > 100000 nM
Compound 4: only a limit was reported; the forecaster's own chance of this, stated with the estimate: 35%; middle value at least 1.3-fold (0.12 log units) away from the limit.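

Compound 4 joins compound 2 at a limit of the read-out in this assay, so the 2-methylphenyl and 2-(trifluoromethyl)phenyl sulfonates both return a limit rather than a number: the limit of > 100000 nM in this assay, at which 2 of the 4 values shown sit. The two steps that can be read give only floors, an at least 1.7-fold higher number from compound 3 to compound 4 (0.23 log units; that floor lies within the scatter) and an at least 1.2-fold higher number from compound 1 to compound 4 (0.11 log units; that floor lies within the scatter), so neither establishes a change beyond the scatter, and the step between the two limits cannot be read. The new result does extend a pattern across these four compounds, with none going against it: both 2-substituted phenyl groups sit at the limit. By contrast, compound 1, with 4-(trifluoromethyl)phenyl, gives 77000 nM, and compound 3, with naphthalen-2-yl, gives 58300 nM.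

For the compounds shown here, with only two compounds at the limit, the pattern cannot separate the place of the substituent on the phenyl ring from the identity of the aryl group as a whole. As far as these compounds go, how an unsubstituted phenyl, a 4-methylphenyl or a 2-methoxyphenyl on this oxygen would read remains open, as does how far above the limit compound 2 and compound 4 actually lie.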